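The source may report more compounds than this note shows. Statements on the series, on what has been measured and on what is new or still open speak of the compounds shown alone.

Measured compounds:
compound 1, `OC[C@H]1O[C@@H](n2cc(F)c3c(-c4ccccc4)ncnc32)[C@H](O)[C@@H]1O`: > 50000 nM
compound 2, `OC[C@H]1O[C@@H](n2cc(F)c3c(-c4ccco4)ncnc32)[C@H](O)[C@@H]1O`: 29000 nM
compound 3, `CCCCCCCCCCCCCCCCCCOP(=O)(O)OC[C@H]1O[C@@H](n2ccc3c(-c4ccccc4)ncnc32)[C@H](O)[C@@H]1O`: > 50000 nM

These three compounds were examined in an ADME assay on MRC5 cells (Homo sapiens) for cytotoxicity, read by MTT assay, with a stated time of 72 h; a lower number here means that less compound is tolerated, a higher number that more compound is tolerated. For compound 1 the result is only a limit of the assay, > 50000 nM. Compound 2 gives a number, 29000 nM. For compound 3, again, only a limit is reported, > 50000 nM. Among the compounds with values here, the single measured step is an at least 1.7-fold lower number from compound 1 to compound 2 (0.23 log units; that floor lies within the scatter), and the change behind it is furan-2-yl in place of phenyl on an aromatic carbon. Its size cannot be read more closely, since the limit of > 50000 nM in this assay, at which 2 of the 3 values shown sit, leaves the starting point open.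

Compound 3 shares with compound 1 the phenyl group; how the two cores differ beyond that is not broken down here. Compound 4, `CCCCCCCCCCCCCCCCCCOP(=O)(O)OC[C@H]1O[C@@H](n2ccc3c(-c4ccco4)ncnc32)[C@H](O)[C@@H]1O`, has not yet been measured in this assay. It stands to compound 3 as compound 2 stands to compound 1: furan-2-yl in place of phenyl on an aromatic carbon, the same change at the same place.

Given that the measured step from compound 1 to compound 2 is an at least 1.7-fold lower number from compound 1 to compound 2 (0.23 log units; that floor lies within the scatter), the step from compound 3 to compound 4 in this assay is expected to be of similar, modest size, an at least 1.2-fold lower number from compound 3 to compound 4 (0.09 log units; that floor lies within the scatter). The estimate for compound 4 in this assay is therefore 40000 nM, with a range from 15000 nM to 100000 nM, and there is a fair chance that the assay will report only a limit for compound 4.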

Compound 4, half-maximal cytotoxic concentration: 45300 nM
Beside the measured number, compound 4's estimate is 1.1-fold (0.05 log units) below it; measured number inside the range.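

In this assay, furan-2-yl in place of phenyl on an aromatic carbon gives an at least 1.1-fold lower number from compound 3 to compound 4 (0.04 log units; that floor lies within the scatter) on the second core, so the change points the same way there as on the first, and nothing in these four compounds speaks against its carrying over in direction. That is as far as the comparison goes, since neither step has a fixed size and each has only a floor that lies within the scatter; whether the change does the same amount on both cores cannot be said: the same change on two cores in this assay, an at least 1.7-fold lower number (0.23 log units; that floor lies within the scatter) from compound 1 to compound 2 and an at least 1.1-fold lower number (0.04 log units; that floor lies within the scatter) from compound 3 to compound 4; the limit leaves it open whether they differ. Both steps start from a compound that gives only a limit, so a real drop in the number on either core is not established, and this is because of the ceiling on the starting values: the limit of > 50000 nM in this assay, at which 2 of the 4 values shown sit.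

The compounds shown leave open how far compound 1 and compound 3 really lie beyond that limit, and so how large either step truly is. They also leave open whether thiophen-2-yl or an amine on the same aromatic carbon, or a shorter chain in place of the long chain of compound 3, would give a step of the same kind.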